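From Phenyl to Naphthalen-1-yl on Compound 3

This account rests on a few compounds, and the source may have more. Where it says the series, first, only, none or still open, it means among the compounds named here.

Of the compounds shown here, three that share one core have been tested in a functional assay on CHO cells for agonist activity at Free fatty acid receptor 1 (Homo sapiens), read by FLIPR and calcium flux, tested at 100 nM; a lower number here means a weaker effect, a higher number a stronger effect of the compound at the concentration tested. Compound 1 `O=C(O)CC1COc2cc(OCc3ncc(-c4ccccc4)s3)ccc21` gives 5.26%, compound 2 `O=C(O)CC1COc2cc(OCc3nc(-c4ccccc4)cs3)ccc21` gives 0.16%, and compound 3 `Cc1nc(-c2ccccc2)sc1COc1ccc2c(c1)OCC2CC(=O)O` gives 54.8%. Compound 3 thus stands highest of the three: it lies beyond the scatter above compound 1, the nearest of the others, and further still above compound 2, the furthest.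

Compound 4 `Cc1nc(-c2cccc3ccccc23)sc1COc1ccc2c(c1)OCC2CC(=O)O` is the next step from compound 3. The change is naphthalen-1-yl in place of phenyl on an aromatic carbon. The new group sits on an aromatic carbon of a five-membered aromatic ring with one nitrogen and one sulfur, two ring bonds from the ring atom that bears a methyl group.

Among the compounds with values here, no measured pair shows what such a change does here, so the expectation rests on compound 3 alone. The step from compound 3 to compound 4 is estimated as a number 3.2 percentage points higher from compound 3 to compound 4 (within the scatter), with no clear direction and possibly none beyond the scatter. For compound 4 the estimate in this assay is 58%, expected to fall between 25% and 85%.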

Compound 4, a percentage reported as activity, at one concentration (the size of the read-out at that concentration, not a potency): 8.53%
For compound 4 the middle estimate is 49.5 percentage points above the measured one; measured number below the stated range.
By their numbers in this assay, from the lowest: compounds 2, 1 and 4 (each within the scatter of the next); then compound 3.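

On an aromatic carbon next to the ring nitrogen and next to the ring sulfur, naphthalen-1-yl in place of phenyl gives a number 46.3 percentage points lower from compound 3 to compound 4 (beyond the scatter) in this assay. Within the data shown here, this is the first measured step at this position, and it shows that the read-out can change strongly with the aromatic group placed there: going from one six-membered aromatic ring of carbon only to 2 such rings removes most of what compound 3 shows. Nothing measured here explains this loss.

Going by these compounds, it remains open how other groups would behave at this position, such as naphthalen-2-yl, pyridin-3-yl or a phenyl ring carrying a fluorine atom or a methoxy group. The read-out also comes from a single concentration, so it leaves open how compound 3 and compound 4 differ in potency.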